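The source may hold more compounds than are shown below. What is called first, only, known or untested is meant among the compounds shown, and "the series" means these compounds.

Measured compounds:
- compound 1, `CCCSc1nc(Cl)c2c(n1)N(CCNC(=O)OC(C)(C)C)C(C(=O)N1CCN(C)CC1)N2`: 59300 nM
- compound 2, `CCCSc1nc(Cl)c2c(n1)N(Cc1ccccc1)C(C(=O)NCCCc1ccccc1)N2`: 16900 nM
- compound 3, `CCCSc1nc(Cl)c2c(n1)N(Cc1ccccc1)C(C(=O)N1CCN(C(=O)OC(C)(C)C)CC1)N2`: 32000 nM

Three compounds sharing one core were measured in a functional assay on MGC-803 cells (Homo sapiens) for antiproliferative activity, read by MTT assay, with a stated time of 72 h; on this read-out higher numbers stand for weaker inhibition and lower numbers for stronger inhibition. Compound 1 gives 59300 nM, which is the highest number of the three. Compound 3 gives 32000 nM, a gap from compound 1 that stays within the scatter of repeated measurements, so nothing can be read into the order of those two. Compound 2 gives 16900 nM, and here the gap from compound 1 lies beyond the scatter, so compound 2 inhibits more strongly than compound 1 in this assay.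

Compound 4, `CCCSc1nc(Cl)c2c(n1)N(CC1CCCCC1)C(C(=O)N1CCN(C)CC1)N2`, has not been measured. It differs from compound 1 in one place: cyclohexyl in place of ((tert-butoxycarbonyl)amino)methyl on a saturated chain carbon bound to a nitrogen on an aromatic ring in a ring. Among the measured compounds shown here, no two measured compounds differ in only one place, so the size of this step cannot be read from a measured pair. Compound 4 keeps the amide part of compound 1, while its group on the ring nitrogen is closer in kind to the benzyl groups of compounds 2 and 3, which both gave lower numbers than compound 1. A modest step toward stronger inhibition is therefore expected, though one that may well stay within the scatter: the step from compound 1 to compound 4 is estimated at a 2.0-fold lower number from compound 1 to compound 4 (0.30 log units; within the scatter). For compound 4 the expected value is 30000 nM, with a range from 10000 nM to 90000 nM.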

Compound 4, half-maximal inhibitory concentration: > 64000 nM
Compound 4: only a limit was reported (the forecaster's own chance of this, stated with the estimate: 10%); middle value at least 2.1-fold (0.32 log units) away from the limit.
By their numbers in this assay, from the lowest: compounds 2, 3 and 1 (each within the scatter of the next, the first and the last beyond it). At a limit, above all of these: compound 4.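

In this assay compound 4 gives no number, only a limit: the limit of > 64000 nM in this assay, at which 1 of the 4 values shown sits. Read as a step, the change from 2-((tert-butoxycarbonyl)amino)ethyl to cyclohexylmethyl, with the amide part kept, gives an at least 1.0-fold higher number from compound 1 to compound 4 (0.03 log units; that floor lies within the scatter), so the floor of this step does not separate the two compounds and the full size of the step stays unknown. What it does show is that, with this amide part, the cyclohexyl group, a carbon-only ring with no hydrogen-bond donor or acceptor, brought no lower number in this place.

The compounds shown leave open how a free primary amine or a carboxylic acid at the end of this chain would read in this assay. They also leave open whether benzyl in this place would give a lower number with the amide part of compound 1 kept.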